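This account rests on a few compounds, and the source may have more. Where it says the series, first, only, none or still open, it means among the compounds named here.

Among the compounds with values here, in an ADME assay on Vero cells (Chlorocebus sabaeus) for cytotoxicity, read by MTT assay, with a stated time of 96 h (a higher number here means that more compound is tolerated, a lower number that less compound is tolerated), compound 1 (`COc1cc(NCc2ccc(C)s2)ccc1-c1cnco1`) gives 24700 nM, the lower of the two numbers so far, and compound 2 (`COc1cc(/N=C/c2ccncc2)ccc1-c1cnco1`) gives 239000 nM, a gap beyond the scatter. Compound 3 (`CCc1ccc(CNc2ccc(-c3cnco3)c(OC)c2)s1`) keeps the core of compound 1 and turns methyl to ethyl: methyl in place of hydrogen on a saturated chain carbon bound to an aromatic carbon, with methyl in place of hydrogen on a saturated chain carbon bound to an aromatic carbon. Within the data shown here, no measured pair shows this change, so no step beyond the scatter is expected in this assay. The estimated step, a 1.1-fold lower number from compound 1 to compound 3 (0.05 log units; within the scatter), stays within the scatter. Compound 3 is expected at 22000 nM, with a range of 9000 nM to 50000 nM.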

Compound 3, half-maximal cytotoxic concentration: 13600 nM
For compound 3 the middle estimate is 1.6-fold (0.21 log units) above the measured one, within the range that was stated.
By their numbers in this assay, from the lowest: compounds 3 and 1 (each within the scatter of the next); then compound 2.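

Methyl to ethyl on the 5-methylthiophen-2-yl group gives the first step that can be read in this assay (a 1.8-fold lower number from compound 1 to compound 3 (0.26 log units; within the scatter)). At this place, on a saturated chain carbon bound to an aromatic carbon, the added methyl therefore leaves compound 3 indistinguishable from compound 1. No measurement at hand bears on the reason for this result. As far as these compounds go, whether the same holds for a longer chain such as propyl remains open, as does the outcome with an amine or a carboxylic acid at this place.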